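Swapping but-2-yn-1-yl for isopropyl on the shared core

This account rests on a few compounds, and the source may have more. Where it says the series, first, only, none or still open, it means among the compounds named here.

- Compound 1 `C#CCOc1noc2c1CNCC2`: 7.6
- Compound 2 `CC#CCOc1noc2c1CNCC2`: 7.6
- Compound 3 `c1ccc(COc2noc3c2CNCC3)cc1`: 7.5

These three compounds were measured in a physicochemical assay for acid dissociation. Compound 2, at 7.6, stands level with compound 1, and compound 3, at 7.5, lies within the scatter of both. The next compound, compound 4 `CC(C)Oc1noc2c1CNCC2`, has not yet been measured. It has isopropyl in place of but-2-yn-1-yl on an oxygen on an aromatic ring. The triple bond therefore leaves with the chain.

For the measured compounds named here, only one measured step changes a single place, no change at the digits printed from compound 1 to compound 2 (within the scatter), and it stays within the scatter. It alters the end of the chain and does not remove the triple bond, so it bears on the new change only indirectly. Compound 3 carries a different group on the same oxygen and gives 7.5, which suggests that the number in this assay may not move much with that group. Going by the values given here, no measured step replaces the chain with a branched one without a triple bond, so the range is kept wide. The expected change is none beyond the scatter, and the estimated step is a number 0.10 log units higher from compound 2 to compound 4 (within the scatter). For compound 4 the estimate is 7.7, with an expected range from 7.4 to 8.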

Compound 4, acid dissociation constant: 7.5
Compound 4: middle estimate off by 0.20 log units, on the high side, and the stated range covers the measured number.
By their numbers in this assay, from the lowest: compounds 3, 4, 1 and 2 (each within the scatter of the next).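

In this assay, the swap that removes the triple bond along with the straight chain gives a number 0.10 log units lower from compound 2 to compound 4 (within the scatter), and the swap of isopropyl for propargyl at the same place gives a number 0.10 log units lower from compound 1 to compound 4 (within the scatter). The earlier single-place step altered only the end of the chain and kept the triple bond, whereas these steps show that a branched group with no triple bond, on an oxygen on an aromatic ring, stays within the scatter of both chains it replaces. No independent measurement is available to explain this result.

All the groups shown on this oxygen are built from carbon and hydrogen alone, which leaves open whether an amine, a carboxylic acid or a longer chain ending in a hydroxyl group at the same place would stay within the scatter in this assay. On these data alone, it also remains open whether a change on the shared core itself, with the oxygen substituent left as it is, would produce a step beyond the scatter.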